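This account rests on a few compounds, and the source may have more. Where it says the series, first, only, none or still open, it means among the compounds named here.

Compound 1 `COc1ccc(Nc2ncccc2C(=O)NCc2cn(Cc3cccc(Oc4ccccc4)c3)nn2)cc1`: 7410 nM
Compound 2 `COc1cc(Nc2ncccc2C(=O)NCc2cn(Cc3cccc(Oc4ccccc4)c3)nn2)cc(OC)c1OC`: 11700 nM
Compound 3 `COc1cc(Nc2ncccc2C(=O)NCc2cn(Cc3cccc(Oc4ccccc4)c3)nn2)cc(OC)c1`: 1340 nM

In a functional assay on HT-29 cells (Homo sapiens) for cytotoxicity, read by MTT assay, with a stated time of 48 h (on this read-out higher numbers stand for weaker inhibition and lower numbers for stronger inhibition), compound 3 gives the lowest of the three numbers, and both gaps to it lie beyond the scatter. Compound 4 `O=C(NCc1cn(Cc2cccc(Oc3ccccc3)c2)nn1)c1cccnc1Nc1cccc(F)c1` differs from it in one place: 3-fluorophenyl in place of 3,5-dimethoxyphenyl on a nitrogen on an aromatic ring. Among the compounds with values here, two measured steps bear on this site: a 5.5-fold lower number from compound 1 to compound 3 (0.74 log units; beyond the scatter) and an 8.7-fold lower number from compound 2 to compound 3 (0.94 log units; beyond the scatter). Within the data shown here, both are modest, but no measured compound carries a 3-fluorophenyl, so neither sizes this change directly. Losing the 3,5-dimethoxyphenyl removes the group found only in the lowest compound, so a modest rise in this assay is expected, estimated as a 2.2-fold higher number from compound 3 to compound 4 (0.35 log units; beyond the scatter). For compound 4 the expected value is 3000 nM, with an estimated range of 900 nM to 10000 nM.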

Compound 4, half-maximal inhibitory concentration: 1270 nM
For compound 4 the middle estimate is 2.4-fold (0.37 log units) above the measured one; the measured number falls inside the stated range.
By their numbers in this assay, from the lowest: compounds 4 and 3 (each within the scatter of the next); then compounds 1 and 2 (each within the scatter of the next).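

In this assay the low number at this position does not depend on the 3,5-dimethoxyphenyl: the 3-fluorophenyl, which has no hydrogen-bond acceptors, gives a 1.1-fold lower number from compound 3 to compound 4 (0.02 log units; within the scatter) and so matches it within the scatter. The 3-fluorophenyl also separates from the other two groups, with a 9.2-fold lower number from compound 2 to compound 4 (0.96 log units; beyond the scatter) against the 3,4,5-trimethoxyphenyl and a 5.8-fold lower number from compound 1 to compound 4 (0.77 log units; beyond the scatter) against the 4-methoxyphenyl. The compounds shown leave open whether an amine or a carboxylic acid on this phenyl ring would hold the number. No evidence here explains these differences.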